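Phenyl to pyridin-4-yl on the sulfur of compound 2

This account rests on a few compounds, and the source may have more. Where it says the series, first, only, none or still open, it means among the compounds named here.

The series shares one core. Compound 1 `Cc1cc(Sc2ccc(Cl)cc2)c(S(C)(=O)=O)cc1C(=O)N=C(N)N` carries a chloro on the aromatic ring attached to the sulfur, and compound 2 `Cc1cc(Sc2ccccc2)c(S(C)(=O)=O)cc1C(=O)N=C(N)N` carries hydrogen in its place. In a functional assay for inhibition of sodium/hydrogen exchanger (Oryctolagus cuniculus) (a lower number here means a stronger inhibitor, a higher number a weaker inhibitor), compound 1 gives 19 nM, and compound 2 gives 14 nM. Going by the values given here, the step of a 1.4-fold lower number from compound 1 to compound 2 (0.13 log units; within the scatter) is within the scatter, so the two compounds cannot be ranked against each other; compound 2 simply shows the lower of the two numbers so far.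

Compound 3 `Cc1cc(Sc2ccncc2)c(S(C)(=O)=O)cc1C(=O)N=C(N)N` has not been measured. It differs from compound 2 by pyridin-4-yl in place of phenyl on a sulfur. Among the compounds with values here, no measured step changes the ring itself; the only step known, a 1.4-fold lower number from compound 1 to compound 2 (0.13 log units; within the scatter), alters a substituent on that same ring and stays within the scatter. On that basis the expected change for compound 3 is small, a 1.8-fold higher number from compound 2 to compound 3 (0.25 log units; within the scatter), with the direction uncertain and likely within the scatter. Compound 3 is therefore estimated at 25 nM, with a range from 8 nM to 80 nM.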

Compound 3, half-maximal inhibitory concentration: 13 nM
The estimate for compound 3 lay 1.9-fold (0.28 log units) above the measured number; the range from low to high includes it.
By their numbers in this assay, from the lowest: compounds 3, 2 and 1 (each within the scatter of the next).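

Going by these compounds alone, until now, only a substituent on the aromatic ring attached to the sulfur had been varied; compound 3 is the first change to the ring itself, and in this assay the step shows a 1.1-fold lower number from compound 2 to compound 3 (0.03 log units; within the scatter). Exchanging phenyl for pyridin-4-yl puts a ring nitrogen and 1 hydrogen-bond acceptor into the group on the sulfur, and the number stays within the scatter of the number for the phenyl compound, so this position tolerates a hetero atom in the ring as well as a chloro on it. The comparison with the chloro compound reads the same way, with a 1.5-fold lower number from compound 1 to compound 3 (0.16 log units; within the scatter), so all three aromatic groups on the sulfur remain unranked, and no evidence on why the ring nitrogen leaves the number within the scatter is available.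

On these data alone, all three compounds keep a six-membered aromatic ring on the sulfur, so it remains open whether that ring is needed at all, for instance whether a cyclohexyl ring or a short alkyl chain would serve in its place. Also open, as far as these compounds go, is how this position would respond to a ring substituent such as an amine or a carboxylic acid.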